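Removing a methyl group from a weakly cytotoxic amidrazone

The compounds below may be only part of what the source reports. "The series", "measured", "known", "first", "only" and "open" are said of these compounds alone.

Measured compounds:
Compound 1, `Cc1ccc(N2CCN/C2=N\N)cc1`, gives 12% in a functional assay on T47D cells (Homo sapiens) for cytotoxicity, with a stated time of 72 h, tested at 10 ug/mL; on this read-out lower numbers stand for a weaker effect and higher numbers for a stronger effect at the one concentration tested.
Compound 2, `O=c1[nH]nc2n(c1=O)CCN2c1ccc(Cl)cc1`, gives 5% in this assay.

Both numbers are small, and the gap between compound 1 and compound 2 lies within the usual scatter of repeated measurements, so neither compound is set apart from the other: compound 1 stands among two numbers that are, for practical purposes, the same and both weak. Among the compounds with values here, no step between two measured compounds that differ in a single place is available here, so there is nothing yet to show how a small change on the aromatic ring shifts the read-out.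

The next compound is compound 3, `N/N=C1\NCCN1c1ccccc1`. It differs from compound 1 in one place: hydrogen in place of methyl on an aromatic carbon. Given that compound 1 gives only 12% and that compound 2, with a different substituent on the same kind of ring, gives 5%, the expectation is that losing the methyl group leaves the weak effect as it is, with no step beyond the scatter from compound 1 to compound 3. The step is expected to be about a number 2 percentage points lower from compound 1 to compound 3 (within the scatter). Compound 3 is estimated at 10%, within a range from 0% to 25%.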

Compound 3, a percentage reported as inhibition, at one concentration (the size of the read-out at that concentration, not a potency): 0%
Compound 3: middle estimate off by 10 percentage points, on the high side; the measured number falls inside the stated range.
By their numbers in this assay, from the lowest: compounds 3, 2 and 1 (each within the scatter of the next, the first and the last beyond it).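

Replacing methyl with hydrogen on the aromatic carbon, para to a group of 7 heavy atoms, gives a number 12 percentage points lower from compound 1 to compound 3 (beyond the scatter), so the position is not silent: removing a single carbon atom is enough to move the read-out beyond the usual scatter. The step is modest, but in this assay compound 3 gives 0%, so the small effect seen with the methyl group in place is absent without it at the one concentration tested, a result that speaks to effect size at that concentration and not to potency. Nothing available here explains why the read-out falls with this change.

On these data alone, with only methyl and hydrogen compared at this place on the shared core, it remains open whether an ethyl group, a methoxy group or an amine on the same carbon would give a larger number than compound 1 or would leave the effect as weak as it is now. As far as these compounds go, it also remains open whether any group at this position can lift the read-out from weak to clearly strong.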